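The source may report more compounds than this note shows. Statements on the series, on what has been measured and on what is new or still open speak of the compounds shown alone.

Working notes on the series. In a functional assay on PC-3 cells (Homo sapiens) for cytotoxicity, read by MTT assay, with a stated time of 72 h (on this read-out lower numbers stand for stronger inhibition and higher numbers for weaker inhibition), compound 1 (`COc1cc2ncnc(Nc3ccc(F)c(Cl)c3)c2cc1NC(=O)/C=C/c1ccc(F)cc1Cl`) gives 32700 nM as its half-maximal inhibitory concentration. Compound 2 (`COc1cc(/C=C/C(=O)Nc2cc3c(Nc4ccc(F)c(Cl)c4)ncnc3cc2O[C@H]2CCOC2)cc(OC)c1OC`) gives 20500 nM in the same read-out. These two values lie within the scatter of each other, so compound 1 stands level with compound 2 and the pair sets no order.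

The next compound to be read is compound 3 (`COc1ccc(/C=C/C(=O)Nc2cc3c(Nc4ccc(F)c(Cl)c4)ncnc3cc2OC)cc1`). Relative to compound 1, the change is 4-methoxyphenyl in place of 2-chloro-4-fluorophenyl on a double-bonded chain carbon bound to a double-bonded chain carbon. The shared core and the rest of compound 1 stay as they are.

Among the compounds with values here, no measured step isolates a change at this place, so the size of this step cannot be calibrated from the data. In this assay no step beyond the scatter is expected, and no direction is favoured. This expectation rests only on compound 2 at 20500 nM and compound 1 at 32700 nM (values within the scatter of each other). The estimated step is a 1.5-fold lower number from compound 1 to compound 3 (0.17 log units; within the scatter) (an expectation, not a measurement). The estimated value for compound 3 is 22000 nM (expected range 8000 nM to 55000 nM).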

Compound 3, half-maximal inhibitory concentration: "not active" (no number reported)
Nothing numeric was reported for compound 3; no gap can be computed for the estimate.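

In this assay, within the data shown here, compound 3 is reported as "not active" without a number; no step from compound 1 to compound 3 can be read. Nothing available bears on this result. The compounds shown leave open how far 4-methoxyphenyl in place of 2-chloro-4-fluorophenyl moves the read-out, and in which direction.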